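Swapping Chloro for Bromo on a Cinnamamide Thiadiazole

The source may hold more compounds than are shown below. What is called first, only, known or untested is meant among the compounds shown, and "the series" means these compounds.

Of the compounds shown here, two sharing one core have been measured in a functional assay on A549 cells (Homo sapiens) for antiproliferative activity, read by MTT assay, with a stated time of 48 h; on this read-out higher numbers stand for weaker inhibition and lower numbers for stronger inhibition. Compound 1 `Cc1ccc(/C=C/C(=O)Nc2nnc(-c3ccc(Cl)cc3)s2)cc1` gives 1.25 ug/mL, and compound 2 `O=C(/C=C/c1ccccc1)Nc1nnc(-c2ccc(Cl)cc2)s1` gives 2.02 ug/mL. Going by the values given here, on these two numbers compound 1 stands at the lower end, but the only known step, a 1.6-fold higher number from compound 1 to compound 2 (0.21 log units; within the scatter), does not separate the two beyond the scatter, so neither can be called the stronger inhibitor.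

Compound 3 `Cc1ccc(/C=C/C(=O)Nc2nnc(-c3ccc(Br)cc3)s2)cc1` is yet to be measured. Its change from compound 1 is bromo in place of chloro on an aromatic carbon. Among the compounds with values here, no measured step touches this position: the one step on record, from compound 1 to compound 2, alters the methyl on the other aromatic ring and lies within the scatter, so it can only suggest that small changes at the periphery of this core have so far left the read-out little moved. Because a 1.6-fold higher number from compound 1 to compound 2 (0.21 log units; within the scatter) is within the scatter, the step expected in this assay is a 1.0-fold higher number from compound 1 to compound 3 (0.02 log units; within the scatter), in no particular direction and not beyond the scatter.

Compound 3 is therefore estimated at 1.3 ug/mL, with a range from 0.6 ug/mL to 2.8 ug/mL.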

Compound 3, half-maximal inhibitory concentration: 1.51 ug/mL
Compound 3: the middle estimate sits 1.2-fold (0.07 log units) below what was measured; the range from low to high includes it.
By their numbers in this assay, from the lowest: compounds 1, 3 and 2 (each within the scatter of the next).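

In this assay, going by these compounds alone, the change from 4-chlorophenyl to 4-bromophenyl gives the first reading at this position of the shared core, and a 1.2-fold higher number from compound 1 to compound 3 (0.08 log units; within the scatter) does not separate the two halogens. The earlier step concerned the methyl on the other aromatic ring, so it said nothing about this site; this result adds that, on the six-membered aromatic ring of carbon only, the group para to a large group can pass from chloro to bromo with the read-out staying within the scatter. Nothing available on these compounds explains this outcome.

The compounds shown leave open whether a group of a different kind at this position, such as an amine, a carboxylic acid or a methoxy group, would shift the number beyond the scatter. As far as these compounds go, it also remains open whether the exchange of chloro for bromo would read the same way with hydrogen in place of the methyl on the other aromatic ring, or whether a longer chain at that site would alter the picture.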